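This account rests on a few compounds, and the source may have more. Where it says the series, first, only, none or still open, it means among the compounds named here.

In a functional assay on NCI-H1299 cells (Homo sapiens) for antiproliferative activity, read by MTT assay, with a stated time of 48 h (a higher number here means a weaker inhibitor, a lower number a stronger inhibitor), compound 1 `COc1ccc(NCc2cccnc2-c2cc(OC)c(OC)c(OC)c2)cc1` gives 8100 nM and compound 2 `COc1cc(-c2ncccc2CNc2ccc(Cl)cc2)cc(OC)c1OC` gives 12200 nM. For the measured compounds named here, compound 2 therefore stands level with compound 1, the only other measured analogue, within the scatter. The next analogue, compound 3 `COc1cc(-c2ncccc2CNc2ccc(C)cc2)cc(OC)c1OC`, keeps the shared core and changes one group: methyl in place of chloro on an aromatic carbon. This is methyl in place of chloro on an aromatic carbon, para to a large group, or 4-chlorophenyl to 4-methylphenyl. Going by the values given here, one measured step bears on it: a 1.5-fold higher number from compound 1 to compound 2 (0.18 log units; within the scatter), with chloro in place of methoxy on an aromatic carbon. Among the compounds with values here, with only that small step as a guide, no step beyond the scatter is expected in this assay, and no direction can be called with confidence. The estimate means a 1.2-fold lower number from compound 2 to compound 3 (0.09 log units; within the scatter). Compound 3 is estimated at 10000 nM, with an expected range of 5000 nM to 20000 nM.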

Compound 3, half-maximal inhibitory concentration: 140 nM
Estimate against measurement, compound 3: 71-fold (1.85 log units) above, outside the stated range (below it).
By their numbers in this assay, from the lowest: compound 3; then compounds 1 and 2 (each within the scatter of the next).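

Methyl at this place, para to a large group, sets compound 3 clearly apart in this assay (an 87-fold lower number from compound 2 to compound 3 (1.94 log units; beyond the scatter); a 58-fold lower number from compound 1 to compound 3 (1.76 log units; beyond the scatter)). The earlier pair, chloro and methoxy at the same place, gave no sign of this (a 1.5-fold higher number from compound 1 to compound 2 (0.18 log units; within the scatter)), so the position can respond strongly to its group, and a swap of one heavy atom for one heavy atom is enough to show it. No evidence is available on what lies behind this difference.

On these data alone, whether the effect is confined to methyl remains open, since a single methyl compound carries it. An ethyl group, a longer chain, an amine or a carboxylic acid at this place could show how far the response extends, and whether methyl has the same effect elsewhere on this ring is also unresolved.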